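A few compounds are considered here, and "the series" means these few. Any claim that something is new, unique, unknown or untested is made for them only; others in the source may bear on it.

Working notes on the series. Among the compounds with values here, in an ADME assay on CHO-K1 cells (Cricetulus griseus) for cytotoxicity, read by MTT assay, with a stated time of 24 h (a lower number here means that less compound is tolerated, a higher number that more compound is tolerated), compound 1 (`S=C(Nc1ccccc1)Nc1ccc2[nH]ccc2c1`) gives 337000 nM, the lower of the two numbers available so far. Compound 2 (`Oc1cccc(NC(=S)Nc2ccc3[nH]ccc3c2)c1`) gives 977000 nM. Compound 3 (`OCc1ccc(NC(=S)Nc2ccc3[nH]ccc3c2)cc1`) departs from compound 1 at one place: hydroxymethyl in place of hydrogen on an aromatic carbon. This is hydroxymethyl in place of hydrogen on an aromatic carbon, para to a large group.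

Within the data shown here, one measured step bears on this change: a 2.9-fold higher number from compound 1 to compound 2 (0.46 log units; beyond the scatter). It is modest and beyond the scatter, and it comes from hydroxy in place of hydrogen on an aromatic carbon. Hydroxymethyl is a different group, and a single step sets no trend, so the guidance is thin. Among the measured compounds shown here, a step in the same direction, toward a higher number in this assay, but somewhat smaller than the one seen with compound 2, is therefore expected, and it may not clear the scatter. The expected step is a 1.8-fold higher number from compound 1 to compound 3 (0.25 log units; within the scatter). For compound 3 the estimated value is 600000 nM, with an expected range of 260000 nM to 1300000 nM.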

Compound 3, concentration lethal to 50% of the cells: 1080000 nM
Compound 3: middle estimate off by 1.8-fold (0.26 log units), on the low side; the range from low to high includes it.
By their numbers in this assay, from the lowest: compound 1; then compounds 2 and 3 (each within the scatter of the next).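

In this assay, hydroxymethyl on an aromatic carbon, para to a large group, gives a 3.2-fold higher number from compound 1 to compound 3 (0.51 log units; beyond the scatter), so an added group at this place moves the number clearly upward rather than leaving it within the scatter. Alongside a 2.9-fold higher number from compound 1 to compound 2 (0.46 log units; beyond the scatter), this makes two single changes from compound 1, hydroxy and hydroxymethyl, that both lead to a higher number, and neither compound shown goes against that direction. Compound 1 therefore stands apart from both compounds carrying a hydroxy-bearing group, although two steps are too few to establish a trend across the series. No available measurement accounts for the size or direction of the step.

The compounds shown leave open whether the oxygen of hydroxymethyl matters, since a plain methyl group or a methoxy group at the same place would be needed to separate the oxygen from the added carbon. They also leave open whether an amine, a carboxylic acid or a longer chain such as hydroxyethyl would follow the same direction, and whether hydroxymethyl would give a similar step elsewhere on the ring.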